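The compounds below may be only part of what the source reports. "The series", "measured", "known", "first", "only" and "open" are said of these compounds alone.

Of the compounds shown here, two have been measured, and a third follows on from the better of them. Compound 1 `NS(=O)(=O)c1cc(-c2nnc(CNC(=O)c3ccccc3)o2)c(Cl)cc1SCc1ccccc1` and compound 2 `NS(=O)(=O)c1cc(-c2nnc(/C=C/c3ccccc3)o2)c(Cl)cc1SCc1ccccc1` share a core and differ in the group on one aromatic carbon. Among the measured compounds shown here, in a functional assay on MCF7 cells (Homo sapiens) for cytotoxicity, read by MTT assay, with a stated time of 72 h (a lower number here means a stronger inhibitor, a higher number a weaker inhibitor), compound 1 gives 66000 nM, while compound 2 gives 16000 nM; the single measured step, a 4.1-fold lower number from compound 1 to compound 2 (0.62 log units; beyond the scatter), goes beyond the scatter. For the measured compounds named here, compound 2 thus has the lower of the two numbers, with compound 1 as its only neighbour.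

Compound 3 `NS(=O)(=O)c1cc(-c2nnc(/C=C/c3cccc(Cl)c3)o2)c(Cl)cc1SCc1ccccc1` carries the change (chloro in place of hydrogen on an aromatic carbon), on an aromatic carbon of a six-membered aromatic ring of carbon only, meta to a large group. Going by the values given here, no measured step bears directly on this change: the one step known concerns a different group at another part of the molecule. For that reason the expected step of a 1.3-fold lower number from compound 2 to compound 3 (0.12 log units; within the scatter) in this assay is small, and compound 3 is estimated to lie close to compound 2 at 12000 nM, within a range of 4000 nM to 40000 nM.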

Compound 3, half-maximal inhibitory concentration: 11000 nM
Compound 3: middle estimate off by 1.1-fold (0.04 log units), on the high side, within the range that was stated.
By their numbers in this assay, from the lowest: compounds 3 and 2 (each within the scatter of the next); then compound 1.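

In this assay, chloro in place of hydrogen on an aromatic carbon of the six-membered aromatic ring of carbon only, meta to a large group, gives a 1.5-fold lower number from compound 2 to compound 3 (0.16 log units; within the scatter) and leaves compound 2 and compound 3 indistinguishable in this read-out. Among the compounds shown here, this is the first direct look at this ring, and it shows that the added chlorine atom, a single heavy atom, has no effect here that can be separated from the usual scatter. Measured against the benzamidomethyl compound, 2-(3-chlorophenyl)ethenyl in place of benzamidomethyl gives a 6.0-fold lower number from compound 1 to compound 3 (0.78 log units; beyond the scatter) and lies beyond the scatter, so compound 3, like compound 2, stays clearly apart from compound 1. Nothing among the data offers an explanation for this result.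

The compounds shown leave open whether a different group at this same place, such as methoxy, a nitrile or an amine, would move the number beyond the scatter from compound 2. They also leave open whether chloro elsewhere on that ring, or a longer chain in place of the ethenyl link, would change the number in this assay at all.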